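Hydrazone aryl variations on a shared urea-ether core

The source may report more compounds than this note shows. Statements on the series, on what has been measured and on what is new or still open speak of the compounds shown alone.

All four compounds share one core and differ only in the aryl group on the hydrazone carbon. Compound 1 `O=C(N/N=C/c1ccccc1)Nc1ccc(Oc2ccnc3[nH]ccc23)cc1` in a functional assay on MCF7 cells (Homo sapiens) for antiproliferative activity, read by MTT assay, with a stated time of 72 h (a higher number here means a weaker inhibitor, a lower number a stronger inhibitor), gives 1510 nM. Compound 2 `O=C(N/N=C/c1ccc(Br)cc1)Nc1ccc(Oc2ccnc3[nH]ccc23)cc1` in this assay gives "not active" (no number reported). Compound 3 `O=C(N/N=C/c1cccc(Cl)c1Cl)Nc1ccc(Oc2ccnc3[nH]ccc23)cc1` in this assay gives "not active" (no number reported), so no single number stands for it, and compound 2 is the one other entry without a number. Compound 4 `O=C(N/N=C/c1ccc(O)cc1Br)Nc1ccc(Oc2ccnc3[nH]ccc23)cc1` is not yet measured; it differs from compound 3 by 2-bromo-4-hydroxyphenyl in place of 2,3-dichlorophenyl on a carbon with a double bond to nitrogen. For the measured compounds named here, no measured step exists between compound 3 and compound 4, and with no number for compound 3 the size of the step cannot be judged. Compound 4 is expected to be a weak inhibitor, estimated at 6000 nM with a range of 1200 nM to 30000 nM, and a reported limit rather than a number is plausible.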

Compound 4, half-maximal inhibitory concentration: "not active" (no number reported)
For compound 4 the study gives words and no number; the estimate stays without a comparison.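

Compound 3 and compound 4 are both reported in this assay as not active, without a number, so no step can be read between them. No evidence bears on this result. The compounds shown leave open how far either aryl group lowers activity.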